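Piperidine to Pyrrolidine Swap Near the Assay Ceiling

A few compounds are considered here, and "the series" means these few. Any claim that something is new, unique, unknown or untested is made for them only; others in the source may bear on it.

Compound 1 `O=C(CC(CC(=O)NC1Cc2ccccc2C1)c1ccccc1)NCCN1CCCCC1` and compound 2 `O=C(CC(CC(=O)NC1Cc2ccccc2C1)c1ccccc1)NCCN1CCCC1` share a core and differ only in pyrrolidin-1-yl in place of piperidin-1-yl on a saturated chain carbon, two bonds along the chain from an amide-type nitrogen. In a functional assay on L02 cells (Homo sapiens) for inhibition (on this read-out higher numbers stand for weaker inhibition and lower numbers for stronger inhibition), compound 1 gives > 100000 nM, which is a limit of the assay and not a number. In this assay compound 2 likewise gives > 100000 nM, again a limit rather than a measured number. The step that the two limits leave unreadable from compound 1 to compound 2 therefore cannot be sized because of the limit of > 100000 nM in this assay, at which 2 of the 3 values shown sit.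

Compound 3 `CCN(C(=O)CC(CC(=O)NCCN1CCCCC1)c1ccc(Cl)cc1)C1Cc2ccccc2C1` carries a different core; the difference between the two cores is not broken down here. In this assay, among the compounds with values here, compound 3 gives 84200 nM, the only value among the three that is a number rather than a limit.

Compound 4 `CCN(C(=O)CC(CC(=O)NCCN1CCCC1)c1ccc(Cl)cc1)C1Cc2ccccc2C1` is not yet measured. It differs from compound 3 by pyrrolidin-1-yl in place of piperidin-1-yl on a saturated chain carbon, two bonds along the chain from an amide-type nitrogen, the same change that separates compound 1 from compound 2. Since the earlier pair only shows two limits, that pair gives no readable size for the step, and compound 3 already sits close to the ceiling of this assay.

Within the data shown here, the step of a 1.2-fold higher number from compound 3 to compound 4 (0.07 log units; within the scatter) is expected to stay small, because the earlier pair offers no measured step to argue otherwise and compound 3 stands at 84200 nM. Compound 4 is estimated at 100000 nM in this assay, with an expected range from 40000 nM to 250000 nM, and a fair chance that only a limit is reported.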

Compound 4, half-maximal inhibitory concentration: 54200 nM
Compound 4: middle estimate off by 1.8-fold (0.27 log units), on the high side; the measured number falls inside the stated range.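

In this assay, within the data shown here, carrying the change from piperidin-1-yl to pyrrolidin-1-yl onto the core of compound 3 gives a 1.6-fold lower number from compound 3 to compound 4 (0.19 log units; within the scatter), so on this core the change produces no step that can be told apart from repeat-measurement noise. Among these compounds, on the core of compound 1, the same change cannot be sized, because both compounds of that pair give a limit of the assay rather than a number: the limit of > 100000 nM in this assay, at which 2 of the 4 values shown sit. The series therefore offers only one readable step for this change, which means that it shows neither that the step carries over from one core to the other with the same size nor that it differs between them.

The compounds shown leave open whether a different amine in place of piperidin-1-yl on the same saturated chain carbon, such as morpholin-4-yl or dimethylamino, would give a step beyond the scatter on the core of compound 3. They also leave open whether a longer chain, such as 3-(pyrrolidin-1-yl)propyl in place of 2-(pyrrolidin-1-yl)ethyl, would move the number clearly away from that of compound 4 in this assay.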